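Swapping bromo for methoxy on a bromophenyl amide

The compounds below may be only part of what the source reports. "The series", "measured", "known", "first", "only" and "open" are said of these compounds alone.

Measured so far in a toxicity assay on the whole organism (strain Icem-CET (SPF Caw)) for cytotoxicity, with Mus musculus as the target; on this read-out higher numbers stand for an effect only at larger amounts of compound and lower numbers for an effect already at smaller amounts:
Compound 1, `C#CCNC(=O)/C(C)=C(\C)c1ccc(Br)cc1`: 180 mg/kg
Compound 2, `C/C(C(=O)NC1CC1)=C(/C)c1ccc(Br)cc1`: 100 mg/kg

Of the compounds shown here, two with a shared core have been tested. Compound 1 gives 180 mg/kg, the highest of the two numbers. Its nearest neighbour, compound 2, gives 100 mg/kg; the step of a 1.8-fold lower number from compound 1 to compound 2 (0.26 log units; within the scatter) lies within the scatter, so the two compounds cannot be told apart on this read-out.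

Compound 3, `C#CCNC(=O)/C(C)=C(\C)c1ccc(OC)cc1`, is not yet measured. It differs from compound 1 in one place: methoxy in place of bromo on an aromatic carbon. Among the compounds with values here, no measured step bears on this change. Within the data shown here, the only known step concerns a group on the amide-type nitrogen, not the aromatic ring, and it stayed within the scatter, so it gives no guidance on what replacing a halogen by an ether group on the ring will do. With nothing pointing in either direction, the sensible expectation is a number close to that of compound 1, with a wide margin.

For compound 3 the expected value in this assay is therefore 180 mg/kg, with a range from 70 mg/kg to 450 mg/kg. This amounts to an expected no change at the digits printed from compound 1 to compound 3 (within the scatter), that is, no step beyond the scatter.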

Compound 3, dose for half-maximal effect: 150 mg/kg
The estimate for compound 3 lay 1.2-fold (0.08 log units) above the measured number; low and high end bracket the measured number.
By their numbers in this assay, from the lowest: compounds 2, 3 and 1 (each within the scatter of the next).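

Replacing bromo with methoxy on the aromatic carbon para to a large group gives, in this assay, a 1.2-fold lower number from compound 1 to compound 3 (0.08 log units; within the scatter), so this swap does not separate the two compounds. Within the data shown here, this is the first measured look at the aromatic ring, as the earlier step concerned only the group on the amide-type nitrogen, and it shows that a swap here can also stay within the scatter, even though 1 heavy atom with no hydrogen-bond acceptor gives way to 2 heavy atoms with 1 hydrogen-bond acceptor. No measurement at hand accounts for this result.

From the compounds shown here alone, this single pair covers only bromo and methoxy at one place on the ring, so it remains open whether an amine, a carboxylic acid or a longer alkoxy chain on the same carbon would give a step beyond the scatter. Going by these compounds, it also remains open whether methoxy would give a similar result on the shared core when cyclopropyl, rather than propargyl, sits on the amide-type nitrogen.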